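Series notes: a methyl step from compound 2

A few compounds are considered here, and "the series" means these few. Any claim that something is new, unique, unknown or untested is made for them only; others in the source may bear on it.

Three compounds on the shared core have been entered so far in a functional assay on MDA-MB-435 cells (Homo sapiens) for inhibition, read by sulforhodamine B assay, with a stated time of 48 h; on this read-out lower numbers stand for stronger inhibition and higher numbers for weaker inhibition. Compound 1 (`CN(c1ccc(Cl)cc1)c1ncnc2c1CCC2`) stands at "not determined" (no result reported). Compound 2 (`Cc1ccc(N(C)c2ncnc3c2CCC3)cc1`) also stands at "not determined" (no result reported), so it has no number and no place in any ranking. Among the compounds with values here, compound 3 (`COc1ccc(N(C)c2ncnc3c2CCC3)cc1`) gives 43 nM, the only number available.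

The next entry is compound 4 (`Cc1ccc(N(C)c2nc(C)nc3c2CCC3)cc1`). The change is methyl in place of hydrogen on an aromatic carbon, between two ring nitrogen atoms. Within the data shown here, no measured pair shows what such a change does, so any expectation here is loose. A step of modest size towards stronger inhibition is expected in this assay, although it cannot be read directly without a number for compound 2. The level itself has a single anchor, compound 3 at 43 nM, and compound 4 is expected to fall somewhat on the weaker side of that anchor, with a wide margin either way. For compound 4 the estimated value is 150 nM, with an expected range of 20 nM to 1200 nM.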

Compound 4, half-maximal inhibitory concentration: 360 nM
The estimate for compound 4 lay 2.4-fold (0.38 log units) below the measured number; the range from low to high includes it.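

In this assay compound 2 stands at "not determined" (no result reported) while compound 4 gives 360 nM and so no step can be read between compound 2 and compound 4. The compounds shown leave open what methyl in place of hydrogen on this aromatic carbon does to inhibition. Nothing at hand bears on a cause for the value of compound 4.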